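The compounds below may be only part of what the source reports. "The series", "measured", "known", "first", "only" and "open" are said of these compounds alone.

Compound 2, `O=C(Nc1ccc(OC(F)F)cc1)c1cccc(/C=C2\CC(=O)N(c3ccccc3)C2=O)c1`, stands in an ADME assay on NCM460 cells (Homo sapiens) for cytotoxicity, read by MTT assay, with a stated time of 72 h (a higher number here means a weaker inhibitor, a lower number a stronger inhibitor), at > 100000 nM, which is a limit of the assay and not a number. Compound 1, `Cc1ccc(NC(=O)c2cccc(/C=C3\CC(=O)N(c4ccccc4)C3=O)c2)cc1C`, gives in this assay > 100000 nM, likewise a limit. Within the data shown here, the only measured step, 4-(difluoromethoxy)phenyl in place of 3,4-dimethylphenyl on an amide-type nitrogen, reads a step that the two limits leave unreadable from compound 1 to compound 2; both of its ends sit at the limit of > 100000 nM in this assay, at which 2 of the 2 values shown sit, so its size cannot be read. Compound 3, `CCc1cccc(NC(=O)c2cccc(/C=C3\CC(=O)N(c4ccccc4)C3=O)c2)c1`, has yet to be measured in this assay. It differs from compound 2 by 3-ethylphenyl in place of 4-(difluoromethoxy)phenyl on an amide-type nitrogen. Nothing measured bears on this change beyond the two limits, and neither variation of the amide-bound aryl group seen so far has brought the series into readable cytotoxicity. The step is therefore expected to be a step that the limit leaves unreadable from compound 2 to compound 3, that is none beyond the scatter. Compound 3 is expected to give 150000 nM, within 50000 nM to 500000 nM, most likely again reported only as a limit.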

Compound 3, half-maximal inhibitory concentration: > 100000 nM
Compound 3 was reported as a limit; the forecaster's own chance of this, stated with the estimate: 75%; the middle value does not contradict the limit.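

Neither step to compound 3, from compound 1 or from compound 2, can be read, because each value is a limit and not a number: the limit of > 100000 nM in this assay, at which 3 of the 3 values shown sit.

The compounds shown leave open whether any amide-bound aryl group gives a readable value in this assay, and how large these changes are.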